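Swapping one methylated pyrazole for another on a shared core

The source may hold more compounds than are shown below. What is called first, only, known or untested is meant among the compounds shown, and "the series" means these compounds.

Measured compounds:
- Compound 1, `Cc1ncccc1-c1cnc(NCc2c(F)ccc3c2CCO3)c2nn(CC#N)c(=O)n12`: 4000 nM
- Compound 2, `Cn1nccc1-c1cnc(NCc2c(F)ccc3c2CCO3)c2cn[nH]c(=O)c12`: 2000 nM
- Compound 3, `CN(c1cccnc1)c1cnc(NCc2c(F)ccc3c2CCO3)n2cnnc12`: 47000 nM

In a physicochemical assay for solubility, read by LC-MS, in phosphate buffer, with a stated time of 24 h, at pH 7.4 (on this read-out lower numbers stand for lower solubility and higher numbers for higher solubility), compound 2 gives 2000 nM, the lowest of the three numbers. Compound 1 is its nearest neighbour, and the gap between the two lies within the usual scatter, so the two cannot be told apart with confidence. Compound 3 stands furthest away, with a gap that lies beyond the scatter.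

Compound 4, `Cc1nn(C)cc1-c1cnc(NCc2c(F)ccc3c2CCO3)c2cn[nH]c(=O)c12`, has not yet been measured in this assay. It differs from compound 2 in one place: 1,3-dimethyl-1H-pyrazol-4-yl in place of 1-methyl-1H-pyrazol-5-yl on an aromatic carbon. The pyrazole that enters carries one more carbon than the one that leaves, with the same count of donors and acceptors. Going by the values given here, no measured pair shows this change, so there is no step to lean on.

The expectation is that a change of this kind moves the number little, if at all, so the step of no change at the digits printed from compound 2 to compound 4 (within the scatter) is expected to stay within the scatter. Compound 4 is therefore estimated at 2000 nM, with a range from 700 nM to 6000 nM.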

Compound 4, solubility: 9000 nM
For compound 4 the middle estimate is 4.5-fold (0.65 log units) below the measured one, and the stated range ends below it.
By their numbers in this assay, from the lowest: compounds 2 and 1 (each within the scatter of the next); then compound 4; then compound 3.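

In this assay, going by these compounds alone, putting 1,3-dimethyl-1H-pyrazol-4-yl in place of 1-methyl-1H-pyrazol-5-yl gives a 4.5-fold higher number from compound 2 to compound 4 (0.65 log units; beyond the scatter), the first step here between compounds that differ in one place. This position on the shared core is therefore not indifferent to which methylated pyrazole it carries, even though both groups have the same counts of donors and acceptors and no net charge, and the entering group adds only one carbon. Nothing available explains why the number moved.

On these data alone, this step combines an extra methyl with a different point of attachment on the pyrazole, so it remains open whether 1-methyl-1H-pyrazol-4-yl, which has one change without the other, would fall nearer compound 2 or compound 4. As far as these compounds go, how an amine such as morpholine would compare at this same place also remains open.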